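A few compounds are considered here, and "the series" means these few. Any claim that something is new, unique, unknown or untested is made for them only; others in the source may bear on it.

Going by the values given here, compound 1 `O=C1C(=O)N(CCCCn2cc(COc3cc(=O)oc4ccccc34)nn2)c2ccc(F)cc21` stands highest of the three numbers measured so far in a functional assay on HCT-116 cells (Homo sapiens) for inhibition, read by sulforhodamine B assay, with a stated time of 48 h, tested at 50 uM (a higher number here means more inhibition of growth at the concentration tested, a lower number less inhibition of growth), where compound 1 gives 67%. In this assay compound 3 `COc1ccc2c(c1)C(=O)C(=O)N2CCCn1cc(COc2cc(=O)oc3ccccc23)nn1` gives 52%, a number lower than that of compound 1 by more than the scatter. In this assay compound 2 `COc1ccc2c(c1)C(=O)C(=O)N2CCCCCn1cc(COc2cc(=O)oc3ccccc23)nn1` gives 25%, further below compound 1 and also beyond the scatter. Among the compounds with values here, compounds 2 and 3 each differ from compound 1 in more than one place, so no single-change step between measured compounds is available. Compound 4 `O=C1C(=O)N(CCCCn2cc(COc3cc(=O)oc4ccccc34)nn2)c2ccc([N+](=O)[O-])cc21` differs from compound 1 by nitro in place of fluoro on an aromatic carbon. Within the data shown here, nothing among the measured compounds isolates this change, so the step is expected to be modest, a number 7 percentage points lower from compound 1 to compound 4 (within the scatter), and may fall within the scatter. Compound 4 is thus expected to give about 60% in this assay, with a range from 40% to 80%.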

Compound 4, percent growth inhibition at one concentration: 53%
Compound 4: the middle estimate sits 7 percentage points above what was measured; the range from low to high includes it.
By their numbers in this assay, from the lowest: compound 2; then compounds 3 and 4 (each within the scatter of the next); then compound 1.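

On an aromatic carbon of the shared core, para to a fused ring, nitro in place of fluoro gives a number 14 percentage points lower from compound 1 to compound 4 (beyond the scatter) in this assay. Going by these compounds alone, this is the first single-change step and shows that growth inhibition at the concentration tested responds to the group at this position. No measured evidence accounts for this step.

A single step cannot show a trend at this position. From the compounds shown here alone, how an amine or a carboxylic acid there would compare with fluoro and nitro remains open.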